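The source may hold more compounds than are shown below. What is called first, only, known or untested is meant among the compounds shown, and "the series" means these compounds.

Compound 1 `Cc1nc(S(C)(=O)=O)ccc1Oc1ncnc(OC2CCN(C(=O)OC(C)C)CC2)c1F`: 21 nM
Compound 2 `Cc1nc(S(C)(=O)=O)ccc1Oc1ncnc(OC2CCN(C(=O)OC3CCC3)CC2)c1F`: 13.6 nM

Within the data shown here, compound 1 stands highest of the two numbers in a functional assay on isolated protein for inhibition of Glucose-dependent insulinotropic receptor (Homo sapiens), read by HTRF and cAMP accumulation; on this read-out lower numbers stand for an effect already at smaller amounts and higher numbers for an effect only at larger amounts of compound; the only other number lies a 1.5-fold lower number from compound 1 to compound 2 (0.19 log units; within the scatter), so the two measured compounds are not separated beyond the usual scatter. Compound 3 `Cc1nc(S(C)(=O)=O)ccc1Oc1ncnc(OC2CCN(C(=O)O[C@@H](C)C(F)(F)F)CC2)c1F` has not yet been measured in this assay. It differs from compound 1 in a single place: 1-(trifluoromethyl)ethyl in place of isopropyl on an oxygen next to a carbonyl group. Among the measured compounds shown here, the one measured step that bears on this change is the one in which the group on the same oxygen was also exchanged, a 1.5-fold lower number from compound 1 to compound 2 (0.19 log units; within the scatter), and that step stayed within the scatter. On this basis, compound 3 is expected to show no step beyond the scatter in this assay relative to compound 1, in either direction. The estimate for compound 3 in this assay is 18 nM, with a range from 7 nM to 45 nM. For compound 3 this estimate means an expected step of a 1.2-fold lower number from compound 1 to compound 3 (0.07 log units; within the scatter).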

Compound 3, half-maximal effective concentration: 9.86 nM
For compound 3 the middle estimate is 1.8-fold (0.26 log units) above the measured one, and the stated range covers the measured number.
By their numbers in this assay, from the lowest: compounds 3, 2 and 1 (each within the scatter of the next, the first and the last beyond it).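

In this assay, the group that replaces isopropyl gives a 2.1-fold lower number from compound 1 to compound 3 (0.33 log units; beyond the scatter), so this position now shows a step beyond the scatter, if only a modest one, which the exchange of isopropyl for cyclobutyl did not. Set against the cyclobutyl group, the new group gives a 1.4-fold lower number from compound 2 to compound 3 (0.14 log units; within the scatter), so these two groups are not separated in this read-out and neither stands apart from the other. Nothing available here accounts for the step.

The compounds shown leave open how the opposite configuration at the defined stereocentre of 1-(trifluoromethyl)ethyl would read, and whether the fluorine atoms themselves matter to the step. From the compounds shown here alone, how a tert-butyl group or a longer chain on this oxygen would read in this assay also remains open.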